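Swapping the Amide Ring Partner Once More

A few compounds are considered here, and "the series" means these few. Any claim that something is new, unique, unknown or untested is made for them only; others in the source may bear on it.

Of the compounds shown here, two sharing one core have been tested so far. Compound 1 `CCN(CC)S(=O)(=O)c1ccc(S(=O)(=O)N2CCC[C@@H](C(=O)N3CCS(=O)(=O)CC3)C2)cc1` carries a 1,1-dioxothiomorpholin-4-yl group on its carbonyl carbon, and in a functional assay on MIA PaCa-2 cells (Homo sapiens) for inhibition, read by MTT assay, with a stated time of 3 days (on this read-out higher numbers stand for weaker inhibition and lower numbers for stronger inhibition), compound 1 gives 220 nM. Compound 2 `CCN(CC)S(=O)(=O)c1ccc(S(=O)(=O)N2CCC[C@@H](C(=O)N3CCC(O)CC3)C2)cc1` carries a 4-hydroxypiperidin-1-yl group in that place, and in this assay compound 2 gives 230 nM. Among the measured compounds shown here, these are the only two numbers known, and the gap between them, a 1.0-fold higher number from compound 1 to compound 2 (0.02 log units; within the scatter), lies within the scatter, so compound 2 cannot be called weaker or stronger than compound 1 on this evidence.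

Compound 3 `CCN(CC)S(=O)(=O)c1ccc(S(=O)(=O)N2CCC[C@@H](C(=O)N3CCOCC3)C2)cc1` is the next variation, and it differs from compound 2 as follows: morpholin-4-yl in place of 4-hydroxypiperidin-1-yl on a carbonyl carbon. For the measured compounds named here, the one measured step that bears on this change is the swap of the ring partner on the carbonyl carbon, which produced a 1.0-fold higher number from compound 1 to compound 2 (0.02 log units; within the scatter) and so no movement beyond the scatter. A second swap of the same kind is therefore expected to behave alike, giving an estimated step of a 1.1-fold higher number from compound 2 to compound 3 (0.04 log units; within the scatter). Compound 3 is expected to give about 250 nM, with a likely range from 120 nM to 520 nM.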

Compound 3, half-maximal inhibitory concentration: 160 nM
Estimate against measurement, compound 3: 1.6-fold (0.19 log units) above, within the range that was stated.
By their numbers in this assay, from the lowest: compounds 3, 1 and 2 (each within the scatter of the next).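

The third ring partner on this carbonyl carbon stays within the scatter of both others in this assay: the change gives a 1.4-fold lower number from compound 2 to compound 3 (0.16 log units; within the scatter) and, measured against the 1,1-dioxothiomorpholin-4-yl compound, a 1.4-fold lower number from compound 1 to compound 3 (0.14 log units; within the scatter). This adds something the first pair could not show, since morpholin-4-yl has 0 hydrogen-bond donors where 4-hydroxypiperidin-1-yl has 1, so on these numbers the hydroxyl hydrogen is not needed to keep the read-out in this range. The position therefore accepts all three six-membered non-aromatic rings without a step beyond the scatter, though no measurement shown here gives a reason for this likeness.

As far as these compounds go, all three partners are closed six-membered rings, so it remains open whether the same holds for an open chain such as diethylamino, or for a ring carrying an amine or a carboxylic acid. The shared core is also the same in all three compounds, which leaves open whether this insensitivity at the carbonyl carbon would persist if another part of the molecule were altered.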